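The source may hold more compounds than are shown below. What is called first, only, known or untested is meant among the compounds shown, and "the series" means these compounds.

Compound 1 `COc1ccc2c(=O)c(/C=C/C(=O)Nc3cccc(Cl)c3)coc2c1` gives in a functional assay on L02 cells (Homo sapiens) for inhibition, read by MTT assay, with a stated time of 48 h (on this read-out higher numbers stand for weaker inhibition and lower numbers for stronger inhibition), a value that is only a limit, > 200000 nM.
Compound 2 `COc1cccc(NC(=O)/C=C/c2coc3cc(OC)ccc3c2=O)c1` gives in this assay likewise a limit, > 200000 nM.
Compound 3 `COc1ccc2c(=O)c(/C=C/C(=O)Nc3ccccc3C)coc2c1` gives in this assay again a limit, > 200000 nM.

Compound 3 thus stands nowhere that can be placed against the others: its value is a limit, and the two further values shown are limits as well. The steps between the measured compounds, a step that the two limits leave unreadable from compound 1 to compound 2, a step that the two limits leave unreadable from compound 1 to compound 3 and a step that the two limits leave unreadable from compound 2 to compound 3, are all unreadable in size because of the limit of > 200000 nM in this assay, at which 3 of the 3 values shown sit.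

Compound 4 `COc1ccc2c(=O)c(/C=C/C(=O)Nc3ccc(F)cc3)coc2c1` differs from compound 3 by 4-fluorophenyl in place of 2-methylphenyl on an amide-type nitrogen. The steps that change the aryl group on the amide nitrogen, a step that the two limits leave unreadable from compound 1 to compound 3 and a step that the two limits leave unreadable from compound 2 to compound 3, bear most directly on this change, but neither has a readable size. For the measured compounds named here, nothing among the measured compounds therefore shows that exchanging one aryl group for another on this nitrogen moves the value off the limit.

The step from compound 3 to compound 4 is accordingly expected to be a number no higher from compound 3 to compound 4 (the limit leaves the size open), that is, nothing beyond the scatter. Compound 4 is estimated at 200000 nM in this assay, with a range from 100000 nM to 400000 nM, and most likely it too will be reported only as a limit.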

Compound 4, half-maximal inhibitory concentration: > 200000 nM
Compound 4 gave a limit, no number; the forecaster's own chance of this, stated with the estimate: 85%; the middle value sits exactly at the limit.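

Compound 4 gives only a limit in this assay, so its steps to compound 1, compound 2 and compound 3 cannot be read in size, because no number stands on either side of them: the limit of > 200000 nM in this assay, at which 4 of the 4 values shown sit. The compounds shown leave open how far apart these four lie, and whether any aryl group on the amide-type nitrogen brings the value off the limit.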